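The source may report more compounds than this note shows. Statements on the series, on what has been measured and on what is new or still open speak of the compounds shown alone.

Measured so far:
compound 1, `Cc1c(F)c(Oc2cccc(C(=N)N)c2)nc(Oc2cccc(C(=O)O)c2)c1F`: > 5000 nM
compound 2, `Cc1c(F)c(Oc2cccc(NS(C)(=O)=O)c2)nc(Oc2cccc(C(=N)N)c2)c1F`: 1900 nM

Compound 1 carries a 3-carboxyphenyl on an oxygen on an aromatic ring of the shared core. In an assay on isolated protein for inhibition of serine protease 1 (Bos taurus) (on this read-out lower numbers stand for stronger inhibition and higher numbers for weaker inhibition), compound 1 stops at the limit of the assay, > 5000 nM, so no number is known for it (the limit of > 5000 nM in this assay, at which 1 of the 2 values shown sits). Compound 2 gives 1900 nM in this assay. Going by the values given here, the one measured step, an at least 2.6-fold lower number from compound 1 to compound 2 (0.42 log units; beyond the scatter), shows that trading the carboxy for methanesulfonamido brings the number off the limit.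

Compound 3, `Cc1c(F)c(Oc2cccc(C(=N)N)c2)nc(Oc2ccc(Cl)c(N(C)C)c2)c1F`, is not yet measured. It differs from compound 1 by 4-chloro-3-(dimethylamino)phenyl in place of 3-carboxyphenyl on an oxygen on an aromatic ring. Among the compounds with values here, only an at least 2.6-fold lower number from compound 1 to compound 2 (0.42 log units; beyond the scatter) bears on this change: both changes take away the carboxy, but compound 3 brings in chloro and dimethylamino instead of methanesulfonamido, so what enters has no measured counterpart. The expectation is a number off the limit, in the direction seen for compound 2, of uncertain size; the estimated step is an at least 3.3-fold lower number from compound 1 to compound 3 (0.52 log units; beyond the scatter). For compound 3 the estimate in this assay is 1500 nM, with a range from 300 nM to 8000 nM.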

Compound 3, inhibition constant: 1000 nM
Beside the measured number, compound 3's estimate is 1.5-fold (0.18 log units) above it; low and high end bracket the measured number.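

In this assay, 4-chloro-3-(dimethylamino)phenyl in place of 3-carboxyphenyl gives an at least 5.0-fold lower number from compound 1 to compound 3 (0.69 log units; beyond the scatter), so a second replacement on an oxygen on an aromatic ring also comes off the limit, and that move is not tied to methanesulfonamido. Compound 2 gives 1900 nM and compound 3 gives 1000 nM, with no order claimed between them, although one replacement carries methanesulfonamido and the other carries chloro and dimethylamino. The value for compound 1 is a limit and not a number, so the step fixes only a minimum size: the limit of > 5000 nM in this assay, at which 1 of the 3 values shown sits.

Whether chloro alone, dimethylamino alone or simply the loss of the carboxy accounts for the step remains open. An unsubstituted phenyl, an aminophenyl or a chlorophenyl on the same oxygen would separate these readings, and a methyl ester of the carboxylic acid would show whether any group at the carboxy site keeps the number at the limit.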